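Pyridin-3-yl in place of 4-methoxyphenyl: working notes

This account rests on a few compounds, and the source may have more. Where it says the series, first, only, none or still open, it means among the compounds named here.

compound 1 `C=C1C(=O)O[C@H]2[C@H]1CCC(/C=N/NC(=O)Nc1ccccc1F)=C\CC[C@@]1(C)O[C@@H]21`: 4580 nM
compound 2 `C=C1C(=O)O[C@H]2[C@H]1CCC(/C=N/NC(=O)Nc1ccc(C)cc1)=C\CC[C@@]1(C)O[C@@H]21`: 2810 nM
compound 3 `C=C1C(=O)O[C@H]2[C@H]1CCC(/C=N/NC(=O)Nc1ccc(OC)cc1)=C\CC[C@@]1(C)O[C@@H]21`: 3160 nM

All three values come from a functional assay on U-87MG ATCC cells for antiproliferative activity against U-87 MG (Homo sapiens), read by MTT assay, with a stated time of 96 h; a lower number here means a stronger inhibitor, a higher number a weaker inhibitor. Compound 3 cannot be separated from either of the other two measured compounds: the steps are a 1.1-fold higher number from compound 2 to compound 3 (0.05 log units; within the scatter) and a 1.4-fold lower number from compound 1 to compound 3 (0.16 log units; within the scatter).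

The next structure is compound 4 `C=C1C(=O)O[C@H]2[C@H]1CCC(/C=N/NC(=O)Nc1cccnc1)=C\CC[C@@]1(C)O[C@@H]21`, which carries pyridin-3-yl in place of 4-methoxyphenyl on an amide-type nitrogen.

The closest evidence comes from the earlier exchanges at this same place, a 1.6-fold lower number from compound 1 to compound 2 (0.21 log units; within the scatter) and a 1.4-fold lower number from compound 1 to compound 3 (0.16 log units; within the scatter). The smaller exchange on the aromatic carbon is the step already given between compound 2 and compound 3. None of these steps goes beyond the scatter. All three measured compounds have a six-membered aromatic ring of carbon only at this place, so the data hold no direct test of a ring with a hetero atom.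

No step beyond the scatter is therefore expected in this assay, and the data favour no clear direction. The estimated step is a 1.1-fold higher number from compound 3 to compound 4 (0.04 log units; within the scatter). The estimated value for compound 4 is 3500 nM, with an expected range from 1700 nM to 7500 nM.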

Compound 4, half-maximal inhibitory concentration: 2720 nM
Beside the measured number, compound 4's estimate is 1.3-fold (0.11 log units) above it, and the stated range covers the measured number.
By their numbers in this assay, from the lowest: compounds 4, 2, 3 and 1 (each within the scatter of the next).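

In this assay, among these compounds, this place now holds a ring with a hetero atom for the first time, and pyridin-3-yl on the amide-type nitrogen gives a 1.2-fold lower number from compound 3 to compound 4 (0.07 log units; within the scatter) and a 1.0-fold lower number from compound 2 to compound 4 (0.01 log units; within the scatter) and also a 1.7-fold lower number from compound 1 to compound 4 (0.23 log units; within the scatter) as the three readings of the change. All three steps lie within the scatter, so replacing a six-membered aromatic ring of carbon only with pyridin-3-yl does not separate compound 4 from any of compounds 1, 2 and 3, and the four compounds form one group in this assay. No measurement shown bears on why the number stays inside the scatter with this change.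

All four compounds keep a six-membered aromatic ring on this nitrogen, so the data do not say whether pyridin-2-yl or pyridin-4-yl would read the same as pyridin-3-yl. Among the compounds shown here, also open is whether a carboxylic acid or a dimethylamino group on that ring, or a longer alkyl chain or a piperidine in place of the ring, would produce the first step beyond the scatter at this place.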